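Aryl ring exchange on the chain carbon of compound 1

The source may report more compounds than this note shows. Statements on the series, on what has been measured and on what is new or still open speak of the compounds shown alone.

Among the measured compounds shown here, compound 1 `CC/C(=C(/c1ccc(/C=C/C(=O)O)cc1)c1cc2ccccc2[nH]1)c1ccc(Cl)cc1` serves as the reference; in a functional assay on MCF7 cells (Homo sapiens) for inhibition (a higher number here means a weaker inhibitor, a lower number a stronger inhibitor), compound 1 gives 343 nM, the highest of the two numbers measured so far. For the measured compounds named here, compound 2 `CC/C(=C(/c1ccc(/C=C/C(=O)O)cc1)c1cc2ccccc2[nH]1)c1ccc(F)cc1Cl` in this assay gives 39 nM, and the step of an 8.8-fold lower number from compound 1 to compound 2 (0.94 log units; beyond the scatter) is the only measured change at this part of the molecule. Compound 3 `CC/C(=C(/c1ccc(/C=C/C(=O)O)cc1)c1cc2ccccc2[nH]1)c1c(C)cccc1Cl` differs from compound 1 by 2-chloro-6-methylphenyl in place of 4-chlorophenyl on a double-bonded chain carbon bound to a double-bonded chain carbon and a saturated chain carbon. The step from compound 1 to compound 2 bears on this change, since it also exchanged 4-chlorophenyl for another substituted phenyl on the same double-bonded chain carbon and gave a lower number beyond the scatter; the entering ring of compound 3 is, however, a different one, so the size of the effect cannot be read directly from it. A lower number than that of compound 1 is expected, and the expected step for compound 3 is a 3.8-fold lower number from compound 1 to compound 3 (0.58 log units; beyond the scatter). Compound 3 is estimated at 90 nM, with a range from 25 nM to 330 nM.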

Compound 3, half-maximal inhibitory concentration: 30 nM
Compound 3: the middle estimate sits 3.0-fold (0.48 log units) above what was measured; measured number inside the range.
By their numbers in this assay, from the lowest: compounds 3 and 2 (each within the scatter of the next); then compound 1.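

Each of the two entering rings now gives a lower number than 4-chlorophenyl: in this assay, 2-chloro-6-methylphenyl gives an 11-fold lower number from compound 1 to compound 3 (1.06 log units; beyond the scatter). The lower number at this double-bonded chain carbon is therefore not limited to 2-chloro-4-fluorophenyl, and both entering rings carry the 2-chloro group that 4-chlorophenyl lacks. The two entering rings are not separated, with a 1.3-fold lower number from compound 2 to compound 3 (0.11 log units; within the scatter), so 6-methyl and 4-fluoro cannot be told apart here, and nothing at hand explains any of these steps.

Going by these compounds, each entering ring differs from 4-chlorophenyl in more than one substituent, so the share of the 2-chloro group in these steps stays open. A plain 2-chlorophenyl ring and a 2-methylphenyl ring at this carbon would be the direct tests.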